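A Ring Methyl Added to a Thymidylate Synthase Inhibitor

The source may hold more compounds than are shown below. What is called first, only, known or untested is meant among the compounds shown, and "the series" means these compounds.

Three measured compounds share one core. In an assay on L1210 cells for inhibition of Thymidylate synthase (Mus musculus) (a lower number here means a stronger inhibitor, a higher number a weaker inhibitor), compound 1 `C#CCN(Cc1ccc2nc(C)nc(O)c2c1)c1ccc(C(=O)N[C@@H](CCC(=O)O)C(=O)N(C)[C@@H](CCC(=O)O)C(=O)O)cc1` gives 11 nM, compound 2 `C#CCN(Cc1cc2c(O)nc(C)nc2cc1C)c1ccc(C(=O)N[C@@H](CCC(=O)O)C(=O)N(C)[C@@H](CCC(=O)O)C(=O)O)c(F)c1` gives 1.1 nM, and compound 3 `Cc1nc(O)c2cc(CN(C)c3ccc(C(=O)N[C@@H](CCC(=O)O)C(=O)N(C)[C@@H](CCC(=O)O)C(=O)O)c(F)c3)ccc2n1` gives 23 nM. Compound 3 therefore shows the highest number of the three, beyond the scatter from compound 1 and far beyond it from compound 2. Compound 4 `Cc1nc(O)c2cc(CN(C)c3ccc(C(=O)N[C@@H](CCC(=O)O)C(=O)N(C)[C@@H](CCC(=O)O)C(=O)O)c(F)c3)c(C)cc2n1` differs from compound 3 in one place: methyl in place of hydrogen on an aromatic carbon. Among the compounds with values here, no measured pair isolates this change, although compound 2, which carries a methyl on its core among several other differences, has the lowest number. A modest move toward a lower number is expected in this assay, a 2.9-fold lower number from compound 3 to compound 4 (0.46 log units; beyond the scatter). Compound 4 is estimated at 8 nM, within 3 nM to 25 nM.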

Compound 4, inhibition constant: 3 nM
For compound 4 the middle estimate is 2.7-fold (0.43 log units) above the measured one; measured number inside the range.
By their numbers in this assay, from the lowest: compound 2; then compound 4; then compound 1; then compound 3.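

In this assay, methyl in place of hydrogen on this aromatic carbon, ortho to a large group, gives a 7.7-fold lower number from compound 3 to compound 4 (0.88 log units; beyond the scatter), so this single change is now seen on its own and lowers the number. With that methyl in place, hydrogen in place of ethynyl on the saturated chain carbon bound to the nitrogen gives a 2.7-fold higher number from compound 2 to compound 4 (0.44 log units; beyond the scatter), so the ethynyl still counts alongside the ring methyl. Nothing available explains why the methyl lowers the number. From the compounds shown here alone, whether an ethyl, a chlorine or a methoxy on the same carbon would do the same remains open.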